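Shifting fluorine from 4-fluorophenyl to 2-fluorophenyl

The source may report more compounds than this note shows. Statements on the series, on what has been measured and on what is new or still open speak of the compounds shown alone.

Measured so far: compound 1 `CCOC(=O)c1cnn(CC(C)O)c1NC(=O)Nc1ccc(F)cc1` and compound 2 `CCOC(=O)c1cnn(CC(O)CC)c1NC(=O)Nc1ccc(F)cc1`.

In a functional assay on cells (Neutrophil, Homo sapiens) for inhibition, with a stated time of 10 min (on this read-out lower numbers stand for stronger inhibition and higher numbers for weaker inhibition), compound 1 gives only a limit, > 10 nM (the limit of > 10 nM in this assay, at which 1 of the 2 values shown sits). Compound 2 gives 3.2 nM. Going by the values given here, the single measured step, an at least 3.1-fold lower number from compound 1 to compound 2 (0.49 log units; beyond the scatter), concerns a methyl on the chain and lies beyond the scatter, but it leaves the aromatic ring untouched. Compound 3 `CCOC(=O)c1cnn(CC(C)O)c1NC(=O)Nc1ccccc1F` differs from compound 1 by 2-fluorophenyl in place of 4-fluorophenyl on an amide-type nitrogen. Among the compounds with values here, no measured step bears on this change, so compound 3 is expected to sit near compound 1, with a step that the limit leaves unreadable from compound 1 to compound 3 estimated as not clearly beyond the scatter. For compound 3 in this assay the estimate is 20 nM, between 5 nM and 100 nM.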

Compound 3, half-maximal inhibitory concentration: 100 nM
The estimate for compound 3 lay 5.0-fold (0.70 log units) below the measured number; the measured number falls inside the stated range.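

No step from compound 1 to compound 3 can be read, as compound 1 gives only a limit: the limit of > 10 nM in this assay, at which 1 of the 3 values shown sits.

The compounds shown leave open whether 2-fluorophenyl in place of 4-fluorophenyl on an amide-type nitrogen changes inhibition at all, and in which direction.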